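The compounds below may be only part of what the source reports. "The series", "measured", "known", "first", "only" and "open" are said of these compounds alone.

In a functional assay with Oryctolagus cuniculus as the target (on this read-out lower numbers stand for stronger inhibition and higher numbers for weaker inhibition), compound 3 `COc1ccc(-c2nc(CNC(=O)C3=NNC(=O)CC3)sc2-c2ccc(OC)cc2)cc1` gives 55 nM, a lower number, beyond the scatter, than compound 2 `C/N=C(/NC)Nc1nc(-c2ccc(OC)cc2)c(-c2ccc(OC)cc2)s1` at 970 nM. Compound 1 `COc1ccc(-c2nc(/N=C(\N)NC3CCCCC3)sc2-c2ccc(OC)cc2)cc1` reads > 1000 nM, which is a limit of the assay. Among the measured compounds shown here, the only measured step, an at least 1.0-fold lower number from compound 1 to compound 2 (0.01 log units; that floor lies within the scatter), concerns a group on an aromatic carbon and lies within the scatter at its floor, so it bears only loosely on what follows. Compound 4 `CNC(=O)NCc1nc(-c2ccc(OC)cc2)c(-c2ccc(OC)cc2)s1` differs from compound 3 by a group of 2 heavy atoms (1 carbon, 1 nitrogen; no ring) in place of a group of 7 heavy atoms (4 carbon, 2 nitrogen, 1 oxygen; one six-membered non-aromatic ring with 2 hetero atoms), on a carbonyl carbon, with methylamino entering on a carbonyl carbon. For the measured compounds named here, no measured step touches that carbonyl carbon. The expectation leans on compound 2, which at 970 nM also lacks the ring of compound 3. A clear rise in this assay is therefore expected, a 4.5-fold higher number from compound 3 to compound 4 (0.66 log units; beyond the scatter). For compound 4 the estimate is 250 nM, with an expected range of 40 nM to 1500 nM.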

Compound 4, half-maximal inhibitory concentration: 22 nM
Beside the measured number, compound 4's estimate is 11-fold (1.06 log units) above it, and the stated range ends above it.
By their numbers in this assay, from the lowest: compound 4; then compound 3; then compound 2. At a limit, above all of these: compound 1.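

On the carbonyl carbon, methylamino can take the place of the six-membered ring group with no loss in this assay: the change gives a 2.5-fold lower number from compound 3 to compound 4 (0.40 log units; beyond the scatter), so that ring is not required for a low number here. The group on the aromatic carbon weighs far more, with a 44-fold lower number from compound 2 to compound 4 (1.64 log units; beyond the scatter). The further step, an at least 45-fold lower number from compound 1 to compound 4 (1.65 log units; beyond the scatter), is only a floor, as its starting value is a limit: the limit of > 1000 nM in this assay, at which 1 of the 4 values shown sits.

Going by these compounds, what a plain amino group, ethylamino or a phenyl ring on that carbonyl carbon would read stays open.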